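The compounds below may be only part of what the source reports. "The series", "measured", "known", "first", "only" and "open" are said of these compounds alone.

In a functional assay on NCI-H460 cells (Homo sapiens) for inhibition, read by sulforhodamine B assay, with a stated time of 48 h (on this read-out lower numbers stand for stronger inhibition of growth and higher numbers for weaker inhibition of growth), compound 1 (`S=C(N/N=C/c1cccs1)Nc1ccc(Cl)cc1`) gives > 100000 nM as a limit of the assay, not a number. For the measured compounds named here, compound 2 (`Cc1ccc(NC(=S)N/N=C/c2cccs2)cc1`) gives 80600 nM in this assay as the only actual number so far. Compound 3 (`CCc1ccc(NC(=S)N/N=C/c2cccs2)cc1`) follows from compound 2 by methyl in place of hydrogen on a saturated chain carbon bound to an aromatic carbon in the form of methyl in place of hydrogen on a saturated chain carbon bound to an aromatic carbon, which also reads methyl to ethyl. Going by the values given here, one measured step bears on this only loosely: methyl in place of chloro on an aromatic carbon gave an at least 1.2-fold lower number from compound 1 to compound 2 (0.09 log units; that floor lies within the scatter) at a different place in the structure. That step has only a floor, set by the limit of > 100000 nM in this assay, at which 1 of the 2 values shown sits, and nothing more. It gives no direction and no ground for expecting a step beyond the scatter in this assay for the new change. The estimated step is a 1.2-fold lower number from compound 2 to compound 3 (0.06 log units; within the scatter) and is expected to stay within the scatter. Compound 3 is expected at 70000 nM in this assay, with an estimated range from 30000 nM to 100000 nM on that read-out.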

Compound 3, concentration for 50% growth inhibition: > 100000 nM
Compound 3 ended at the assay's limit (the forecaster's own chance of this, stated with the estimate: 20%); at least 1.4-fold (0.15 log units) between middle value and limit.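

In this assay compound 3 gives > 100000 nM, which is a limit of the assay and not a number. Methyl to ethyl, on a saturated chain carbon bound to an aromatic carbon, gives an at least 1.2-fold higher number from compound 2 to compound 3 (0.09 log units; that floor lies within the scatter), so this change shows no gain in growth inhibition over compound 2 on this read-out, and how far the number rises remains unknown. The step between compound 1 and compound 3 cannot be read, which leaves compound 2 as the only compound with an actual number and every comparison in the series bounded from one side only: the limit of > 100000 nM in this assay, at which 2 of the 3 values shown sit.

Still open, going by these compounds, is whether any group in place of the methyl of compound 2, such as an amine, a methoxy or a carboxylic acid, would bring the read-out clearly below the limit and beyond the scatter. Also open, on these data alone, is whether a longer chain than ethyl would stay at the limit, and whether a change elsewhere on the shared core would move the number more than the changes seen so far.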